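The compounds below may be only part of what the source reports. "The series", "measured", "known", "first", "only" and "open" are said of these compounds alone.

Of the compounds shown here, three built on one shared core have been measured in a physicochemical assay for solubility, with a stated time of 18 h, at pH 7.4; a higher number here means a more soluble compound, a lower number a less soluble compound. Compound 1 `COc1ccccc1Oc1ccc2c(NCCCNCc3ccco3)ccnc2c1` gives 14500 nM, compound 2 `c1ccc(-c2ccc3c(NCCCNCc4ccco4)ccnc3c2)cc1` gives 32000 nM, and compound 3 `c1coc(CNCCCNc2ccnc3cc(-c4cccc5ccccc45)ccc23)c1` gives 32000 nM. Compound 3 stands level with compound 2 at the digits given, the two together the highest of the three, and the gap to the lowest reads a 2.2-fold higher number from compound 1 to compound 3 (0.34 log units; beyond the scatter). The step to compound 4 `c1coc(CNCCCNc2ccnc3cc(C4CCCCC4)ccc23)c1` is cyclohexyl in place of naphthalen-1-yl on an aromatic carbon. Of the measured steps, a 2.2-fold higher number from compound 1 to compound 2 (0.34 log units; beyond the scatter) and a 2.2-fold higher number from compound 1 to compound 3 (0.34 log units; beyond the scatter) were modest, while no change at the digits printed from compound 2 to compound 3 (within the scatter) stayed within the scatter; none of them puts a non-aromatic ring in place of aromatic rings, so they bear on this change only loosely. The expectation is therefore a step of no change at the digits printed from compound 3 to compound 4 (within the scatter) in this assay, not beyond the scatter. Compound 4 is estimated at 32000 nM, with a range from 14000 nM to 72000 nM.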

Compound 4, solubility: 4200 nM
Compound 4: the middle estimate sits 7.6-fold (0.88 log units) above what was measured; measured number below the stated range.
By their numbers in this assay, from the lowest: compound 4; then compound 1; then compounds 2 and 3 (each within the scatter of the next).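

At this aromatic carbon in this assay, cyclohexyl is set apart from all three groups that carry an aromatic ring, with a 7.6-fold lower number from compound 3 to compound 4 (0.88 log units; beyond the scatter) and a 7.6-fold lower number from compound 2 to compound 4 (0.88 log units; beyond the scatter) and also a 3.5-fold lower number from compound 1 to compound 4 (0.54 log units; beyond the scatter). Phenyl and naphthalen-1-yl could not be told apart here, yet the position does respond when a non-aromatic ring of carbon only enters. Nothing at hand accounts for this drop. Still open, on these data alone, is whether a non-aromatic ring containing nitrogen, such as piperidinyl or morpholinyl, would stay near compound 4 or return to the level of compounds 2 and 3.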